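Adding a Second Chloro to the Core of Compound 1

The source may report more compounds than this note shows. Statements on the series, on what has been measured and on what is new or still open speak of the compounds shown alone.

Compound 1 `ClCc1cccc(Cn2cnc3ncnc(Cl)c32)c1` carries a chloromethyl-bearing benzyl group on a chlorinated fused core. In a functional assay on MCF7 cells (Homo sapiens) for cytotoxicity, read by sulforhodamine B assay, with a stated time of 48 h (on this read-out higher numbers stand for weaker inhibition of growth and lower numbers for stronger inhibition of growth), compound 1 gives 3980 nM, the lowest of the two numbers recorded so far. Compound 2 `ClCc1ccc(Cn2cnc3nc(Cl)nc(Cl)c32)cc1`, which differs both in where the chloromethyl group sits on the benzyl ring and in carrying a second chloro on the core, gives 17000 nM. For compound 3 `ClCc1ccccc1Cn1cnc2ncnc(Cl)c21` the assay reports only a limit, > 100000 nM. Compound 4 `ClCc1cccc(Cn2cnc3nc(Cl)nc(Cl)c32)c1` has not yet been measured; relative to compound 1 it has chloro in place of hydrogen on an aromatic carbon. Going by the values given here, no measured pair differs by this change alone. The step expected here is a 1.5-fold higher number from compound 1 to compound 4 (0.18 log units; within the scatter), that is, none beyond the scatter or at most a modest weakening. Compound 4 is therefore expected to give 6000 nM, within 2000 nM to 20000 nM.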

Compound 4, concentration for total growth inhibition: 4070 nM
For compound 4 the middle estimate is 1.5-fold (0.17 log units) above the measured one; the measured number falls inside the stated range.
By their numbers in this assay, from the lowest: compounds 1 and 4 (each within the scatter of the next); then compound 2. At a limit, above all of these: compound 3.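

In this assay, placing chloro on the aromatic carbon between two ring nitrogen atoms gives a 1.0-fold higher number from compound 1 to compound 4 (0.01 log units; within the scatter), so this position takes a chloro group with no change beyond the scatter. Compound 2 could not show this, as it differs from compound 1 in two places. Nothing measured here explains the absence of a change.

Going by these compounds, whether an amine, a methoxy group or a longer chain at this position would also leave the number unchanged stays open. So does whether chloro behaves the same way with the chloromethyl group elsewhere on the benzyl ring.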